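Swapping One Pyridine Group on Compound 2

This account rests on a few compounds, and the source may have more. Where it says the series, first, only, none or still open, it means among the compounds named here.

Going by the values given here, in a physicochemical assay for solubility, in phosphate buffer, at pH 6.5 (a lower number here means a less soluble compound, a higher number a more soluble compound), compound 1 (`CCOc1cc(CN2CCC(NC(=O)c3ccc(NC)nc3)CC2)cc(OCC)c1F`) gives 330 ug/mL as the higher of the two numbers so far. Compound 2 (`CCOc1cc(CN2CCC(NC(=O)c3ccc(Cl)nc3)CC2)cc(OCC)c1-c1ccc(F)cc1`) gives 76 ug/mL as the lower number, and the gap between the two lies beyond the usual scatter of repeat measurements. Compound 3 (`CCOc1cc(CN2CCC(NC(=O)c3cncc(C)c3)CC2)cc(OCC)c1-c1ccc(F)cc1`) has not been measured yet. It differs from compound 2 in one place, with 5-methylpyridin-3-yl in place of 6-chloropyridin-3-yl on a carbonyl carbon. Among the compounds with values here, compound 1 and compound 2 differ in more than one place, so no measured pair shows this swap alone. A small rise in this assay is expected, probably within the scatter, and the estimated step of a 1.4-fold higher number from compound 2 to compound 3 (0.16 log units; within the scatter) is only a rough guess. Compound 3 is estimated at 110 ug/mL with an expected range from 45 ug/mL to 280 ug/mL for now.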

Compound 3, solubility: 94 ug/mL
Compound 3: middle estimate off by 1.2-fold (0.07 log units), on the high side; the range from low to high includes it.
By their numbers in this assay, from the lowest: compounds 2 and 3 (each within the scatter of the next); then compound 1.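

In this assay, going by these compounds alone, the swap of 6-chloropyridin-3-yl for 5-methylpyridin-3-yl on the carbonyl carbon gives a 1.2-fold higher number from compound 2 to compound 3 (0.09 log units; within the scatter) and is the first view of this one change on its own. At this place, the two groups cannot be told apart by this measurement, even though they differ in both the atom they carry and where it sits on the ring. No measurement at hand explains why the two compounds read alike.

From the compounds shown here alone, whether the same holds for a very different group at this place, such as a carboxylic acid or a morpholine, remains open. Compound 1 differs from both in more than one place, so what lies behind its 330 ug/mL in this assay also stays unresolved.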